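The compounds below may be only part of what the source reports. "The series", "measured", "known", "first", "only" and "open" are said of these compounds alone.

Working notes on the series. In an ADME assay on THP-1 cells (Homo sapiens) for cytotoxicity (on this read-out higher numbers stand for weaker inhibition and lower numbers for stronger inhibition), compound 1, `COc1ccccc1-c1nnc(-c2ccc(C(=O)N/N=C/c3ccc([N+](=O)[O-])cc3)cc2)o1`, gives 203000 nM. Compound 2, `COc1ccccc1-c1nnc(-c2ccc(C(=O)N/N=C/c3ccccn3)cc2)o1`, gives 67000 nM in this assay, and compound 3, `COc1ccc(O)c(/C=N/NC(=O)c2ccc(-c3nnc(-c4ccccc4OC)o3)cc2)c1`, gives 303000 nM. Compound 2 stands lowest of the measured compounds in this assay: the step of a 3.0-fold lower number from compound 1 to compound 2 (0.48 log units; beyond the scatter) and the step of a 4.5-fold higher number from compound 2 to compound 3 (0.66 log units; beyond the scatter) both lie beyond the scatter, while the step of a 1.5-fold higher number from compound 1 to compound 3 (0.17 log units; within the scatter) lies within it.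

Compound 4, `COc1ccccc1-c1nnc(-c2ccc(C(=O)N/N=C/c3ccc(O)c(O)c3)cc2)o1`, is not yet measured in this assay. It differs from compound 2 as follows: 3,4-dihydroxyphenyl in place of pyridin-2-yl on a carbon with a double bond to nitrogen. Among the measured compounds shown here, the steps that bear on this are the two in which pyridin-2-yl is exchanged against a substituted phenyl on the carbon with a double bond to nitrogen, and both point the same way: the reverse of a 3.0-fold lower number from compound 1 to compound 2 (0.48 log units; beyond the scatter) and the step of a 4.5-fold higher number from compound 2 to compound 3 (0.66 log units; beyond the scatter) are modest rises beyond the scatter. The change to 3,4-dihydroxyphenyl is therefore expected to give a modest rise in this assay as well, of about a 3.0-fold higher number from compound 2 to compound 4 (0.47 log units; beyond the scatter). Compound 4 is expected to give about 200000 nM in this assay, with a range from 80000 nM to 500000 nM.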

Compound 4, half-maximal inhibitory concentration: 100000 nM
Beside the measured number, compound 4's estimate is 2.0-fold (0.30 log units) above it, and the stated range covers the measured number.
By their numbers in this assay, from the lowest: compounds 2 and 4 (each within the scatter of the next); then compounds 1 and 3 (each within the scatter of the next).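

The result shows that, at the carbon with a double bond to nitrogen, exchanging pyridin-2-yl for a substituted phenyl does not always move the number in this assay beyond the scatter: 3,4-dihydroxyphenyl leaves compound 4 within it (a 1.5-fold higher number from compound 2 to compound 4 (0.17 log units; within the scatter)). The substitution on the phenyl therefore counts at this place, since 3,4-dihydroxyphenyl stands apart from both of the other phenyl groups (a 3.0-fold lower number from compound 3 to compound 4 (0.48 log units; beyond the scatter); a 2.0-fold lower number from compound 1 to compound 4 (0.31 log units; beyond the scatter)). The four compounds now fall into two pairs, compounds 2 and 4 at the lower numbers and compounds 1 and 3 at the higher, so pyridin-2-yl no longer stands alone and neither the presence of a ring nitrogen nor a hydroxyl group on the phenyl sorts the series, as compound 3 also carries a hydroxyl group yet lies in the higher pair.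

Open, going by these compounds, are how 4-hydroxyphenyl, pyridin-3-yl or a phenyl carrying an amine or a carboxylic acid would fall at this place, and whether both hydroxyl groups of 3,4-dihydroxyphenyl are needed for compound 4 to stay with compound 2. No measurement at hand explains why the compounds divide into these two pairs.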